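Swapping pyridin-4-yl for pyridin-3-yl on compound 1

A few compounds are considered here, and "the series" means these few. Any claim that something is new, unique, unknown or untested is made for them only; others in the source may bear on it.

Values measured in a functional assay on MIA PaCa-2 cells (Homo sapiens) for antiproliferative activity, read by MTT assay, with a stated time of 24 h (a higher number here means a weaker inhibitor, a lower number a stronger inhibitor), are these
compound 1 `COc1ccc(-c2noc(-c3ccncc3)n2)cc1OC1CCCC1` gives 9330 nM
compound 2 `COc1ccc(-c2noc(Cc3c[nH]c4ccccc34)n2)cc1OC1CCCC1` gives 9560 nM
compound 3 `COc1cc(-c2noc(-c3ccncc3)n2)ccc1OCc1ccccc1` gives > 1000000 nM (a limit)

In this assay compound 1 and compound 2 cannot be told apart, as their values lie within the usual scatter. For compound 3 the entry > 1000000 nM is a limit of the assay and not a number.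

Compound 4 `COc1ccc(-c2noc(-c3cccnc3)n2)cc1OC1CCCC1` has the same atoms as compound 1, joined differently, with the change pyridin-3-yl in place of pyridin-4-yl on an aromatic carbon on the shared core. Among the measured compounds shown here, no measured pair shows a change of this kind, so the expectation starts from compound 1 at 9330 nM and assumes no shift in this assay beyond the scatter. The expected 1.1-fold higher number from compound 1 to compound 4 (0.03 log units; within the scatter) is therefore small, though uncertain. Compound 4 is estimated at 10000 nM with an expected range of 3000 nM to 50000 nM for the coming measurement.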

Compound 4, half-maximal inhibitory concentration: > 1000000 nM
Compound 4: a limit, no number; the forecaster's own chance of this, stated with the estimate: 15%; at least 100-fold (2.00 log units) between middle value and limit.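

Pyridin-3-yl in place of pyridin-4-yl, with no atom gained or lost, gives an at least 100-fold higher number from compound 1 to compound 4 (2.03 log units; beyond the scatter) in this assay. Among the compounds shown here, this shows that activity at this position depends on how the pyridine ring is attached, not only on which atoms are present, something the earlier compounds could not show. The value of compound 4 is a limit, so the step has a floor but no known size: the limit of > 1000000 nM in this assay, at which 2 of the 4 values shown sit.

On these data alone, whether a plain phenyl ring or an aminomethyl group on this carbon would hold the activity of compound 1 stays open. So does whether any group here could give a clearly lower number.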